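Dithiocarbamate series: ethyl to methyl on the amine

The compounds below may be only part of what the source reports. "The series", "measured", "known", "first", "only" and "open" are said of these compounds alone.

Measured so far:
compound 1 `CN1CCN(C(=S)SCC2=CCOC2=O)CC1` — 40500 nM
compound 2 `CCNC(=S)SCC1=CCOC1=O` — 30600 nM
compound 3 `Cc1ccc(NC(=S)SCC2=CCOC2=O)cc1` — 93500 nM

All three were tested in a functional assay on PC-3 cells (Homo sapiens) for antiproliferative activity, read by MTT assay, with a stated time of 72 h; a lower number here means a stronger inhibitor, a higher number a weaker inhibitor. Compound 2 gives 30600 nM, the lowest of the three numbers. Against compound 1 the gap lies within the scatter, so the two cannot be ranked. Compound 3, at 93500 nM, sits beyond the scatter above compound 2 and is the weaker inhibitor of that pair. For the measured compounds named here, no step between two measured compounds differs in a single place, so no measured single change is available for calibration.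

Compound 4 `CNC(=S)SCC1=CCOC1=O` has not been measured. The change from compound 2 is hydrogen in place of methyl on a saturated chain carbon bound to an amide-type nitrogen. The shared core, the thiocarbonyl, the sulfur linker and the lactone portion are kept; only the ethyl on the amine shrinks to a methyl.

With no measured step of this kind in the set, the expectation is a step of no more than the scatter, in either direction, with a slight lean toward a higher number given how small the alkyl change is. The step from compound 2 to compound 4 is expected to be a 1.2-fold higher number from compound 2 to compound 4 (0.07 log units; within the scatter). Compound 4 is estimated at 36000 nM, with a range from 15000 nM to 85000 nM.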

Compound 4, half-maximal inhibitory concentration: 76500 nM
Estimate against measurement, compound 4: 2.1-fold (0.33 log units) below; measured number inside the range.
By their numbers in this assay, from the lowest: compounds 2, 1, 4 and 3 (each within the scatter of the next, the first and the last beyond it).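

In this assay, the ethyl to methyl change gives the series its first measured single-place step: a 2.5-fold higher number from compound 2 to compound 4 (0.40 log units; beyond the scatter). This step is modest but lies beyond the scatter, so hydrogen in place of methyl on a saturated chain carbon bound to an amide-type nitrogen is not a silent change, and in this pair the ethylamino compound is the stronger inhibitor. Nothing available on this pair accounts for the step, so it stands as an observation without an explanation.

On these data alone, a single pair gives a direction for this one change and no trend along the alkyl chain, so it remains open whether activity would keep improving, level off or reverse with a longer chain such as propyl or butyl, or with a branched group such as isopropyl, in place of the ethyl. As far as these compounds go, it is also open how a plain amino group, with no alkyl chain on the nitrogen, would compare with the ethylamino and methylamino compounds, and whether a terminal hydroxyl or carboxylic acid on the ethyl chain would be tolerated.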